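Adding a Ring Methyl to the Best Compound

A few compounds are considered here, and "the series" means these few. Any claim that something is new, unique, unknown or untested is made for them only; others in the source may bear on it.

Measured in a functional assay on the whole organism for agonist activity, with Mus musculus as the target (a higher number here means that more compound is needed for the effect, a lower number that less compound is needed), so far
- compound 1 `O=C1NCCN1CC#CCn1ccnc1` gives 17.3 mg/kg
- compound 2 `Cc1cncn1CC#CCN1CCNC1=O` gives > 100 mg/kg (a limit of the assay, not a number)
- compound 3 `CN1CCN(CC#CCn2ccnc2)C1=O` gives 1.4 mg/kg

Compound 3 has the lowest number of the three (a 12-fold lower number from compound 1 to compound 3 (1.09 log units; beyond the scatter)). Compound 4 `Cc1cncn1CC#CCN1CCN(C)C1=O` differs from it in one place (methyl in place of hydrogen on an aromatic carbon): methyl in place of hydrogen on an aromatic carbon. The same change has been measured once (an at least 5.7-fold higher number from compound 1 to compound 2 (0.76 log units; beyond the scatter)). As far as these compounds go, for compound 2 that step ends at the limit of > 100 mg/kg in this assay, at which 1 of the 3 values shown sits, so its full size remains unknown. The other measured step is a change elsewhere and offers no guide. A clearly higher number is therefore expected, with an estimated step of a 14-fold higher number from compound 3 to compound 4 (1.15 log units; beyond the scatter) in this assay. Compound 4 is expected at 20 mg/kg (5 mg/kg to 100 mg/kg).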

Compound 4, dose for half-maximal effect: 14 mg/kg
Beside the measured number, compound 4's estimate is 1.4-fold (0.15 log units) above it; the range from low to high includes it.
By their numbers in this assay, from the lowest: compound 3; then compounds 4 and 1 (each within the scatter of the next). At a limit, above all of these: compound 2.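

In this assay, methyl in place of hydrogen on this aromatic carbon now has a full size, a 10-fold higher number from compound 3 to compound 4 (1.00 log units; beyond the scatter), whereas the earlier step on the other core ended at a limit. The higher number thus appears on two cores, though their sizes cannot be compared: the same change on two cores in this assay, an at least 5.7-fold higher number (0.76 log units; beyond the scatter) from compound 1 to compound 2 and a 10-fold higher number (1.00 log units; beyond the scatter) from compound 3 to compound 4; the limit leaves it open whether they differ Methyl on the amide-type nitrogen lowers the number on the core already carrying the aromatic methyl, an at least 7.1-fold lower number from compound 2 to compound 4 (0.85 log units; beyond the scatter), but this step starts from a limit, so only its direction and minimum size are known.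

As far as these compounds go, how an ethyl, a chlorine or a hydroxymethyl on this aromatic carbon would compare with methyl stays open.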